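The source may hold more compounds than are shown below. What is called first, only, known or untested is meant among the compounds shown, and "the series" means these compounds.

Of the compounds shown here, three from this series have been measured in an ADME assay on MDCK cells (Canis lupus familiaris) for cytotoxicity, read by MTT assay, with a stated time of 48 h; on this read-out lower numbers stand for higher toxicity in this test and higher numbers for lower toxicity in this test. Compound 1 `COc1ccc([C@H]2CC(C)(O)[C@@H]3CC[C@@H](C)C[C@H]3O2)cc1` gives 689000 nM in that test. Compound 2 `COc1ccc([C@H]2CC(C)(O)[C@@H]3CC[C@@H](C)C[C@H]3O2)cc1OC` differs from compound 1 by the change (methoxy in place of hydrogen on an aromatic carbon). In this assay compound 2 gives > 937000 nM, which is a limit of the assay and not a number. The step of an at least 1.3-fold higher number from compound 1 to compound 2 (0.13 log units; that floor lies within the scatter) therefore has only a floor, set by the limit of > 937000 nM in this assay, at which 1 of the 3 values shown sits. Compound 3 `C[C@@H]1CC[C@@H]2[C@@H](C1)O[C@@H](c1ccc(O)cc1)CC2(C)O` differs from compound 1 by the change (hydrogen in place of methyl on an oxygen on an aromatic ring). In this assay compound 3 gives 127000 nM, so the step is a 5.4-fold lower number from compound 1 to compound 3 (0.73 log units; beyond the scatter).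

Compound 4 `COc1ccc([C@H]2CC(C)(O)[C@@H]3CC[C@@H](C)C[C@H]3O2)cc1O` has not yet been measured. It stands to compound 2 as compound 3 stands to compound 1: the change is hydrogen in place of methyl on an oxygen on an aromatic ring, the same change as from compound 1 to compound 3, with the surroundings of the place described in the same words. The two cores differ by methoxy in place of hydrogen on an aromatic carbon. The earlier step was a 5.4-fold lower number from compound 1 to compound 3 (0.73 log units; beyond the scatter). On that single measured pair alone, a step of similar size is expected from the second pair, an at least 4.6-fold lower number from compound 2 to compound 4 (0.67 log units; beyond the scatter). Only a limit is known for compound 2, so the starting point is itself uncertain. Compound 4 is therefore estimated at 200000 nM in this assay, with an expected range from 80000 nM to 700000 nM.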

Compound 4, half-maximal cytotoxic concentration: 738000 nM
Estimate against measurement, compound 4: 3.7-fold (0.57 log units) below, and the stated range ends below it.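

Compound 2 gives > 937000 nM in this assay, which is a limit of the assay and not a number. On the core of compound 2, the change from methoxy to hydroxy can therefore be read only as an at least 1.2-fold lower number from compound 2 to compound 4 (0.10 log units; that floor lies within the scatter), while the step of a 1.1-fold higher number from compound 1 to compound 4 (0.03 log units; within the scatter) leaves compound 4 and compound 1 indistinguishable in this test. Set side by side, the two cases of the same change neither show that its size carries over from one core to the other nor show that it fails to do so: the same change on two cores in this assay, a 5.4-fold lower number (0.73 log units; beyond the scatter) from compound 1 to compound 3 and an at least 1.2-fold lower number (0.10 log units; that floor lies within the scatter) from compound 2 to compound 4; the limit leaves it open whether they differ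

Within the data shown here, compound 3 and compound 4 give only two cases of this change, and one of them rests on a limit, so it remains open how large the step is on the second core and whether it would match the first if compound 2 had a true number. Also open, going by these compounds, is how an amine or a carboxylic acid in place of the hydroxy, or a longer chain such as ethoxy in place of the methoxy, would read in this assay.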